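The source may hold more compounds than are shown below. What is called first, only, known or untested is meant among the compounds shown, and "the series" means these compounds.

Measured compounds:
- compound 1 `COc1ccc(-c2cc3nccc(-c4cc(OC)c(OC)c(OC)c4)n3n2)cc1[N+](=O)[O-]`; in a functional assay on HCT-116 cells (Homo sapiens) for inhibition, read by CCK-8 assay, with a stated time of 48 h (on this read-out lower numbers stand for stronger inhibition and higher numbers for weaker inhibition), compound 1 gives > 10000 nM, which is a limit of the assay rather than a number.
- compound 2 `COc1ccc(-c2cc3nccc(-c4cc(OC)c(OC)c(OC)c4)n3n2)cc1F`; compound 2 gives 2840 nM.
- compound 3 `COc1cc(-c2ccnc3cc(-c4ccc(-c5cnn(C)c5)cc4)nn23)cc(OC)c1OC`; compound 3 gives 2110 nM.

Among the two values that are numbers, compound 2 stands highest, but its nearest neighbour, compound 3, lies within the scatter of it. Compound 1 sits at the limit of > 10000 nM in this assay, at which 1 of the 3 values shown sits.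

The compound still to be measured is compound 4 `COc1cc(-c2ccnc3cc(-c4cn(C)c5ccccc45)nn23)cc(OC)c1OC`. It differs from compound 2 in one place: 1-methyl-1H-indol-3-yl in place of 3-fluoro-4-methoxyphenyl on an aromatic carbon.

Among the compounds with values here, only one measured step is available, an at least 3.5-fold lower number from compound 1 to compound 2 (0.54 log units; beyond the scatter), and it concerns a change of one substituent on the same phenyl ring rather than an exchange of the whole ring, so it bears only loosely on the step to compound 4. Compound 3 shows that a different aryl group in that same place gives a value within the scatter of compound 2, which points to a small effect of such exchanges.

Compound 4 is therefore expected to lie close to compound 2, with a 1.6-fold lower number from compound 2 to compound 4 (0.20 log units; within the scatter) estimated to stay within the scatter. The estimate for compound 4 is 1800 nM, with a range from 600 nM to 6000 nM.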

Compound 4, half-maximal inhibitory concentration: 762 nM
The estimate for compound 4 lay 2.4-fold (0.37 log units) above the measured number, and the stated range covers the measured number.
By their numbers in this assay, from the lowest: compound 4; then compounds 3 and 2 (each within the scatter of the next). At a limit, above all of these: compound 1.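

In this assay, the exchange on the aromatic carbon of the five-membered ring with 2 nitrogen gives a 3.7-fold lower number from compound 2 to compound 4 (0.57 log units; beyond the scatter). Within the data shown here, until now, the only step beyond the scatter was a change of one substituent on the phenyl ring; this step shows that replacing the whole 3-fluoro-4-methoxyphenyl group with 1-methyl-1H-indol-3-yl can also shift the number beyond the scatter, so the place responds to the ring system it carries as well as to a substituent on a phenyl ring. Nothing in the available evidence bears on the reason for this step.

The compounds shown leave open which part of the entering group matters: the methyl on the ring nitrogen, which could be tested with the unmethylated 1H-indol-3-yl, or the five-membered ring itself, which could be tested with a benzofuranyl or a naphthyl group in the same place. They also leave open whether an amine or a carboxylic acid on the six-membered ring of the indole would keep the lower number, and whether the step would hold in cells other than those of this one assay.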